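Adding One Hydroxy Group to a Compound at the Limit

The compounds below may be only part of what the source reports. "The series", "measured", "known", "first", "only" and "open" are said of these compounds alone.

Of the compounds shown here, two sharing one core have been tested in a functional assay on BIU87 cells (Homo sapiens) for cytotoxicity, read by MTT assay; a higher number here means a weaker inhibitor, a lower number a stronger inhibitor. Compound 1 `C=C1C[C@]23C[C@@]1(O)CC[C@H]2[C@@]12C=C[C@H](O)[C@](C)(C(=O)O1)[C@H]2[C@@H]3C(=O)OCc1ccccc1` gives > 100 ug/mL, which is a limit of the assay and not a number. Compound 2 `C=C1C[C@]23C[C@@]1(OC(C)=O)CC[C@H]2[C@@]12C=C[C@H](OC(C)=O)[C@](C)(C(=O)O1)[C@H]2[C@@H]3C(=O)OCc1ccccc1` gives > 100 ug/mL, which is also a limit. Going by these compounds, compound 2 therefore stands at the limit of > 100 ug/mL in this assay, at which 2 of the 2 values shown sit, and its true strength remains unknown.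

Compound 3 `C=C1[C@H](O)[C@]23C[C@@]1(OC(C)=O)CC[C@H]2[C@@]12C=C[C@H](OC(C)=O)[C@](C)(C(=O)O1)[C@H]2[C@@H]3C(=O)OCc1ccccc1` differs from compound 2 by one change: hydroxy in place of hydrogen on a saturated ring carbon. In short, hydroxy takes the place of hydrogen on a saturated ring carbon. Among the measured compounds shown here, no measured step shows what this change does here, so only a modest move towards stronger inhibition is expected, and the estimated step is an at least 1.2-fold lower number from compound 2 to compound 3 (0.09 log units; that floor lies within the scatter). In this assay compound 3 is estimated at 80 ug/mL, with an expected range of 20 ug/mL to 200 ug/mL, though the result may again be only a limit.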

Compound 3, half-maximal inhibitory concentration: > 100 ug/mL
Compound 3: only a limit was reported; the forecaster's own chance of this, stated with the estimate: 60%; middle value at least 1.2-fold (0.09 log units) away from the limit.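

In this assay compound 3 gives > 100 ug/mL, which is a limit and not a number. Compound 2 also stands at a limit, so no step can be read between compound 2 and compound 3. The compounds shown leave open how strongly each one inhibits, and whether hydroxy in place of hydrogen changes that at all: the limit of > 100 ug/mL in this assay, at which 3 of the 3 values shown sit.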